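This account rests on a few compounds, and the source may have more. Where it says the series, first, only, none or still open, it means among the compounds named here.

Measured so far:
- compound 1, `CC1=NN(C(=O)CSc2ccccc2)[C@@H](c2cc(Br)cc(Br)c2O)C1`: 24100 nM in a functional assay on SGC-7901 cells (Homo sapiens) for cytotoxicity, read by MTT assay, with a stated time of 48 h; on this read-out higher numbers stand for weaker inhibition and lower numbers for stronger inhibition
- compound 2, `O=C(CSCc1ccco1)N1N=C(c2cc3ccccc3oc2=O)C[C@@H]1c1ccccc1C(F)(F)F`: 10300 nM in this assay

Of these two, compound 1 gives the highest number, meaning the weaker cell-killing effect. Compound 2 gives the lower number, and the gap between the two lies beyond the usual scatter of repeated measurements. The two compounds differ in many places at once. Their values therefore say nothing about any single change.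

Compound 3, `CC1=NN(C(=O)CSc2ccc(Br)cc2)[C@@H](c2cc(Br)cc(Br)c2O)C1`, has not yet been measured. It differs from compound 1 in one place: bromo in place of hydrogen on an aromatic carbon. Among the compounds with values here, no pair of measured compounds shows what this kind of change does here, so there is no measured step to lean on. My expectation is a small step, downward if anything, and possibly none beyond the scatter. I estimate for compound 3 a value of 18000 nM, within a range from 6000 nM to 60000 nM, which corresponds to an expected step of a 1.3-fold lower number from compound 1 to compound 3 (0.13 log units; within the scatter).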

Compound 3, half-maximal inhibitory concentration: 8210 nM
Compound 3: middle estimate off by 2.2-fold (0.34 log units), on the high side, within the range that was stated.
By their numbers in this assay, from the lowest: compounds 3 and 2 (each within the scatter of the next); then compound 1.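

In this assay, within the data shown here, the first single change that can be read shows that this ring position is not indifferent: bromo in place of hydrogen, turning phenylsulfanyl into (4-bromophenyl)sulfanyl, gives a 2.9-fold lower number from compound 1 to compound 3 (0.47 log units; beyond the scatter), a modest step toward stronger inhibition. So a change on this outer aromatic ring, far from being lost in the usual scatter, can shift the cell-killing effect, though this rests on one pair of compounds only. No measurement here explains how the added bromo produces this shift.

The compounds shown leave open whether chloro, a methoxy group or an amine at the same place would move the number in the same direction. They also leave open whether bromo at another place on this ring, or on a different core, would give a similar step.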